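Trimming the furan from compound 1

The compounds below may be only part of what the source reports. "The series", "measured", "known", "first", "only" and "open" are said of these compounds alone.

Compound 1 `CC1(c2ccc(-c3ccco3)cc2)CC(S(=O)(=O)c2ccc(F)cc2)=C(c2ccc(/C(N)=N\O)cc2)O1` is the most tolerated-in-reverse point of this small set: in an ADME assay on HepG2 cells (Homo sapiens) for cytotoxicity, read by MTT assay, with a stated time of 72 h (a lower number here means that less compound is tolerated, a higher number that more compound is tolerated), compound 1 gives 7010 nM, the lowest of the three numbers. Compound 2 `CC1(Cc2ccccc2)CC(S(=O)(=O)c2cccc(C(F)(F)F)c2)=C(c2ccc(/C(N)=N\O)cc2)O1` gives 33400 nM in this assay, and compound 3 `CC1(Cc2ccccc2)CC(S(=O)(=O)c2c(F)cccc2F)=C(c2ccc(/C(N)=N\O)cc2)O1` gives 91400 nM. Among the measured compounds shown here, the only single-point step among the measured compounds, a 2.7-fold higher number from compound 2 to compound 3 (0.44 log units; beyond the scatter), concerns the aryl group on the sulfonyl sulfur and so does not touch the part of the molecule that changes here. Between compound 1 and compound 2 more than one place differs, so their values show only that compound 2 lies well above compound 1.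

Compound 4 `CC1(c2ccccc2)CC(S(=O)(=O)c2ccc(F)cc2)=C(c2ccc(/C(N)=N\O)cc2)O1` is compound 1 with one group removed: hydrogen in place of furan-2-yl on an aromatic carbon. The change sits on the aromatic carbon para to a large group, leaving a plain phenyl on the shared core. For the measured compounds named here, no measured step in this assay isolates this change, so the expectation rests on the fact that every other compound shown sits above compound 1 and that compound 4 is the smallest of the four. He therefore expects a moderate step up, a 2.1-fold higher number from compound 1 to compound 4 (0.33 log units; beyond the scatter), for compound 4 in this assay. His estimate for compound 4 is 15000 nM, with a range from 6000 nM to 40000 nM.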

Compound 4, half-maximal cytotoxic concentration: 68300 nM
For compound 4 the middle estimate is 4.6-fold (0.66 log units) below the measured one; measured number above the stated range.
By their numbers in this assay, from the lowest: compound 1; then compound 2; then compounds 4 and 3 (each within the scatter of the next).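

In this assay, replacing furan-2-yl with hydrogen gives a 9.7-fold higher number from compound 1 to compound 4 (0.99 log units; beyond the scatter), the first step shown at this position, on an aromatic carbon para to a large group. The low number of compound 1 therefore goes with the furan-2-yl group in this pair, as the sulfonyl aryl group and the shared core stay the same, and this single change moves the number further than the change on the sulfonyl sulfur, a 2.7-fold higher number from compound 2 to compound 3 (0.44 log units; beyond the scatter). Nothing measured on these compounds accounts for the size of the step.

The compounds shown leave open whether the lower number belongs to furan-2-yl in particular or would come with other groups on this carbon, such as a methoxy group, an amine or a second phenyl ring. From the compounds shown here alone, compounds 2 and 3 differ from compound 4 in more than one place, so it also remains open how the 4-(furan-2-yl)phenyl to phenyl change would read alongside other aryl groups on the sulfonyl sulfur.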